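This account rests on a few compounds, and the source may have more. Where it says the series, first, only, none or still open, it means among the compounds named here.

Working notes on the series in a functional assay on MDA-MB-231 cells (Homo sapiens) for cytotoxicity, read by MTT assay, with a stated time of 72 h; a higher number here means a weaker inhibitor, a lower number a stronger inhibitor.

Of the compounds shown here, three carry a number so far. Compound 2 `CN1CCN(CCCCn2c3c(c4ccccc42)C(=O)c2c[n+]([O-])c4ccccc4c2C3=O)CC1` gives 110 nM in this assay, the lowest of the three numbers. Compound 1 `O=C1c2c[n+]([O-])c3ccccc3c2C(=O)c2c1c1ccccc1n2Cc1cn([C@@H]2C[C@H](O)[C@@H](CO)O2)nn1` gives 130 nM, within the scatter of compound 2. Within the data shown here, compound 3 `CN(C)CCCCn1c2c(c3ccccc31)C(=O)c1c[n+]([O-])c3ccccc3c1C2=O` gives 350 nM, and the one single-point step in the set, a 3.2-fold higher number from compound 2 to compound 3 (0.50 log units; beyond the scatter), shows that a change on the chain at its far end can move the number beyond the scatter.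

Compound 4 `O=C1c2c[n+]([O-])c3ccccc3c2C(=O)c2c1c1ccccc1n2Cc1cn(C[C@@H](O)CO)nn1` is not yet measured. Its difference from compound 2 is 1-(2,3-dihydroxypropyl)-1H-1,2,3-triazol-4-yl in place of 3-(4-methylpiperazin-1-yl)propyl on a saturated chain carbon bound to an aromatic nitrogen. Among the measured compounds shown here, no measured step covers this exchange: the step from compound 2 to compound 3 alters the chain four bonds out from the aromatic nitrogen, whereas here the whole chain is replaced. The closest point of comparison is compound 1, which also carries a 1H-1,2,3-triazol-4-yl on the saturated chain carbon bound to an aromatic nitrogen; it sits within the scatter of compound 2, as compound 1 gives 130 nM. On that basis the expected step of a 1.4-fold higher number from compound 2 to compound 4 (0.13 log units; within the scatter) is small, with no clear direction beyond the scatter. For compound 4 in this assay the estimate is 150 nM, expected to fall between 60 nM and 400 nM.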

Compound 4, half-maximal inhibitory concentration: 670 nM
Compound 4: middle estimate off by 4.5-fold (0.65 log units), on the low side, outside the stated range (above it).
By their numbers in this assay, from the lowest: compounds 2 and 1 (each within the scatter of the next); then compounds 3 and 4 (each within the scatter of the next).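

In this assay the triazole on the saturated chain carbon bound to an aromatic nitrogen does not alone set the number: with 2,3-dihydroxypropyl in place of 4-hydroxy-5-(hydroxymethyl)oxolan-2-yl on an aromatic nitrogen, the series shows a 5.2-fold higher number from compound 1 to compound 4 (0.71 log units; beyond the scatter) and thus a substituent on that triazole can move the number beyond the scatter. The exchange of 3-(4-methylpiperazin-1-yl)propyl for 1-(2,3-dihydroxypropyl)-1H-1,2,3-triazol-4-yl gives a 6.1-fold higher number from compound 2 to compound 4 (0.78 log units; beyond the scatter) and also lies beyond the scatter, while the same entering group against 3-(dimethylamino)propyl gives a 1.9-fold higher number from compound 3 to compound 4 (0.28 log units; within the scatter) and stays within it, so the size of this exchange depends on the group that leaves. No measurement at hand bears on the reason for these steps.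

Open, going by these compounds, is whether a 2-hydroxyethyl group or a carboxylic acid in place of 2,3-dihydroxypropyl on the triazole would give a number closer to compound 1 or to compound 4. Also open, on these data alone, is how the opposite configuration at the defined stereocentre of 2,3-dihydroxypropyl would read in this assay and whether that stereocentre matters at all.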